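The source may report more compounds than this note shows. Statements on the series, on what has been measured and on what is new or still open speak of the compounds shown alone.

Within the data shown here, in a functional assay on L1210 cells (Mus musculus) for cytotoxicity, with a stated time of 48 h (on this read-out higher numbers stand for weaker inhibition and lower numbers for stronger inhibition), compound 2 `O=Cc1c(-c2ccc([N+](=O)[O-])cc2)nc2sc(Cc3ccc(Cl)cc3)nn12` gives 15000 nM, the lower of the two numbers at hand; its nearest neighbour, compound 1 `O=Cc1c(-c2ccc(Cl)cc2Cl)nc2sc(Cc3ccc(Cl)cc3)nn12`, gives 82000 nM, and the single measured step, a 5.5-fold lower number from compound 1 to compound 2 (0.74 log units; beyond the scatter), concerns a different part of the molecule. Compound 3 `N#CSc1c(-c2ccc([N+](=O)[O-])cc2)nc2sc(Cc3ccc(Cl)cc3)nn12` differs from compound 2 by cyanosulfanyl in place of formyl on an aromatic carbon. Among the measured compounds shown here, no measured step touches this position, so nothing here supports a shift beyond the scatter in this assay. Compound 3 is therefore expected to land near the same value, a step of no change at the digits printed from compound 2 to compound 3 (within the scatter), with an estimate of 15000 nM and a range from 4000 nM to 60000 nM.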

Compound 3, half-maximal inhibitory concentration: 50000 nM
The estimate for compound 3 lay 3.3-fold (0.52 log units) below the measured number; the measured number falls inside the stated range.
By their numbers in this assay, from the lowest: compound 2; then compounds 3 and 1 (each within the scatter of the next).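

At this position, on the five-membered aromatic ring, the group does count in this assay: cyanosulfanyl in place of formyl gives a 3.3-fold higher number from compound 2 to compound 3 (0.52 log units; beyond the scatter) and so weaker inhibition. With the 4-nitrophenyl group held constant, formyl is therefore the better of these two groups here. No measurement at hand gives a cause for this shift. The compounds shown leave open how an amine, a carboxylic acid or a longer chain would fare at this position. As far as these compounds go, whether this change would give a similar step alongside 2,4-dichlorophenyl also stays open.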